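One Group Exchanged, Three Measurements to Lean On

The source may report more compounds than this note shows. Statements on the series, on what has been measured and on what is new or still open speak of the compounds shown alone.

Three compounds share one core and differ only in a single group on the aromatic ring. In a functional assay on L1210 cells (Mus musculus) for inhibition, read by MTT assay (a higher number here means a weaker inhibitor, a lower number a stronger inhibitor), compound 1 `CCOC(=O)c1ccc(NC(=O)N2CC2C#N)cc1` gives 9700 nM, compound 2 `N#CC1CN1C(=O)Nc1ccccc1` gives 11000 nM, and compound 3 `N#CC1CN1C(=O)Nc1ccc(C(F)(F)F)cc1` gives 7100 nM. Compound 3 carries the lowest of the three numbers, yet a 1.4-fold lower number from compound 1 to compound 3 (0.14 log units; within the scatter) and a 1.5-fold lower number from compound 2 to compound 3 (0.19 log units; within the scatter) both fall within the scatter, so nothing sets it apart. Compound 4 `N#CC1CN1C(=O)Nc1ccc(S(N)(=O)=O)cc1` arises from compound 3 by sulfamoyl in place of trifluoromethyl on an aromatic carbon. Among the measured compounds shown here, the steps that bear on this change, a 1.4-fold lower number from compound 1 to compound 3 (0.14 log units; within the scatter) and a 1.5-fold lower number from compound 2 to compound 3 (0.19 log units; within the scatter), each exchanged the same position and moved nothing beyond the scatter; no measured compound carries a sulfamoyl group. The expected step is therefore a 1.2-fold higher number from compound 3 to compound 4 (0.08 log units; within the scatter). Compound 4 is estimated at 8500 nM, between 3000 nM and 25000 nM.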

Compound 4, half-maximal inhibitory concentration: > 38000 nM
Compound 4: a limit, no number; the forecaster's own chance of this, stated with the estimate: 5%; middle value at least 4.4-fold (0.65 log units) away from the limit.
By their numbers in this assay, from the lowest: compounds 3, 1 and 2 (each within the scatter of the next). At a limit, above all of these: compound 4.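

Of the groups shown, only sulfamoyl moves the number beyond the scatter: an at least 5.3-fold higher number from compound 3 to compound 4 (0.72 log units; beyond the scatter) and an at least 3.4-fold higher number from compound 2 to compound 4 (0.53 log units; beyond the scatter) and an at least 3.9-fold higher number from compound 1 to compound 4 (0.59 log units; beyond the scatter) all count as at least modest steps. This position is therefore not indifferent to its group, as hydrogen, ethoxycarbonyl and trifluoromethyl alone had suggested. Compound 4 stands only as a limit, not a number: the limit of > 38000 nM in this assay, at which 1 of the 4 values shown sits.

As far as these compounds go, how far beyond that limit compound 4 truly lies stays open, so these steps have a floor but no known size. Also open, from the compounds shown here alone, is whether a carboxylic acid or an amine on the same aromatic carbon would behave like sulfamoyl or like trifluoromethyl.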